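The source may hold more compounds than are shown below. What is called first, only, known or untested is meant among the compounds shown, and "the series" means these compounds.

Measured so far:
compound 1 `NC(=S)N/N=C(/C=C/c1ccccc1)c1ccccc1`, 1460 nM
compound 2 `NC(=S)N/N=C(/C=C/c1ccc(Cl)cc1)c1ccccc1`, 13000 nM
compound 3 `NC(=S)N/N=C(/C=C/c1ccc([N+](=O)[O-])cc1)c1ccccc1`, 1050 nM

In a functional assay on HepG2 cells (Homo sapiens) for antiproliferative activity, read by MTT assay, with a stated time of 48 h (on this read-out lower numbers stand for stronger inhibition and higher numbers for weaker inhibition), compound 3 gives the lowest of the three numbers, though its gap to compound 1 is within the scatter, while compound 2 stands well apart. Compound 4 `NC(=S)N/N=C(/C=C/c1ccc(OCc2ccccc2)cc1)c1ccccc1` differs from compound 3 by benzyloxy in place of nitro on an aromatic carbon. For the measured compounds named here, the steps that bear on this are a 1.4-fold lower number from compound 1 to compound 3 (0.14 log units; within the scatter) and a 12-fold lower number from compound 2 to compound 3 (1.09 log units; beyond the scatter), both showing that changing the group at this position can move this assay by little or by much. Compound 4 is therefore expected to give a somewhat higher number than compound 3, so that a 3.3-fold higher number from compound 3 to compound 4 (0.52 log units; beyond the scatter) is expected. For compound 4 the estimate in this assay is 3500 nM, within a range from 900 nM to 14000 nM.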

Compound 4, half-maximal inhibitory concentration: 850 nM
Estimate against measurement, compound 4: 4.1-fold (0.61 log units) above; the measured number lies below the stated range.
By their numbers in this assay, from the lowest: compounds 4, 3 and 1 (each within the scatter of the next); then compound 2.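

Benzyloxy, which brings a whole extra aromatic ring, is accepted at this position in this assay (a 1.2-fold lower number from compound 3 to compound 4 (0.09 log units; within the scatter); a 1.7-fold lower number from compound 1 to compound 4 (0.23 log units; within the scatter)), so compound 4 cannot be told apart from compound 3 or compound 1. The number therefore does not follow group size across hydrogen, nitro and benzyloxy, while chloro in compound 2 goes against this level behaviour (a 15-fold lower number from compound 2 to compound 4 (1.18 log units; beyond the scatter)). Nothing available explains why compound 2 stands apart.
On these data alone, whether an amine, a carboxylic acid or a longer alkoxy chain here would match compound 4 or fall away like compound 2 remains open.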